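Series notes: carbamate, urea and acetamide on the ethylamino nitrogen

This account rests on a few compounds, and the source may have more. Where it says the series, first, only, none or still open, it means among the compounds named here.

Of the compounds shown here, three have been measured in an ADME assay on Caco-2 cells (Homo sapiens) for permeability, read by LC-MS, with a stated time of 2 h, tested at 3 uM; a higher number here means that the compound crosses the layer faster, a lower number that the compound crosses the layer more slowly. Compound 1 `CCN(c1cc2oc(-c3ccc(F)cc3)c(C(=O)NC)c2cc1-c1cc(F)c(OC)c(C(=O)NC2(c3ncccn3)CC2)c1)S(C)(=O)=O` gives 29 nm/s. Compound 2 `CCN(C(=O)OC)c1cc2oc(-c3ccc(F)cc3)c(C(=O)NC)c2cc1-c1ccc(OC)c(C(=O)NC2(c3ncccn3)CC2)c1`, in which the ethylamino nitrogen carries a carbamate, gives 24 nm/s. Compound 3 `CCN(C(=O)N(C)C)c1cc2oc(-c3ccc(F)cc3)c(C(=O)NC)c2cc1-c1ccc(OC)c(C(=O)NC2(c3ncccn3)CC2)c1`, in which the same nitrogen carries a dimethylcarbamoyl group, gives 20 nm/s in this assay. Its number lies within the scatter of both compound 1 and compound 2, so no ordering among the three can be read from these data.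

Within the data shown here, the one single-point step measured so far, a 1.2-fold lower number from compound 2 to compound 3 (0.08 log units; within the scatter), shows that exchanging the group on this carbonyl carbon left the read-out essentially unchanged.

Compound 4 `CCN(C(C)=O)c1cc2oc(-c3ccc(F)cc3)c(C(=O)NC)c2cc1-c1ccc(OC)c(C(=O)NC2(c3ncccn3)CC2)c1` is not yet measured. It differs from compound 3 by methyl in place of dimethylamino on a carbonyl carbon. Among the measured compounds shown here, the only comparable step in the set, from methoxy to dimethylamino on the same carbonyl carbon, stayed inside the scatter, and nothing else measured here bears on an acetyl in this position. The expectation for compound 4 is therefore a step of a 1.3-fold higher number from compound 3 to compound 4 (0.10 log units; within the scatter) in this assay, a change not beyond the scatter, with a slight lean upward. Compound 4 is expected to give 25 nm/s, with a range from 12 nm/s to 50 nm/s.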

Compound 4, apparent permeability: < 15 nm/s
Compound 4 was reported as a limit; the forecaster's own chance of this, stated with the estimate: 5%; middle value at least 1.6-fold (0.22 log units) from the limit.
By their numbers in this assay, from the lowest: compounds 3, 2 and 1 (each within the scatter of the next). At a limit, below all of these: compound 4.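

In this assay, among these compounds, compound 4, with methyl on the carbonyl carbon, is the one compound reported as a limit and not as a number: the limit of < 15 nm/s in this assay, at which 1 of the 4 values shown sits. Set against its two closest neighbours, this limit gives an at least 1.3-fold lower number from compound 3 to compound 4 (0.12 log units; that floor lies within the scatter) and an at least 1.6-fold lower number from compound 2 to compound 4 (0.20 log units; that floor lies within the scatter), so these floors alone do not carry the change past the scatter, although the true step may be larger than either. Among the compounds shown here, the earlier exchange on this carbonyl carbon, a 1.2-fold lower number from compound 2 to compound 3 (0.08 log units; within the scatter), left both compounds with measurable numbers, whereas acetyl on the ethylamino nitrogen is the first group here to reach the limit, so this position can no longer be taken as indifferent to what the carbonyl carries.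

As far as these compounds go, how far the true value of compound 4 lies under its limit remains open, and with it whether the step from dimethylcarbamoyl to acetyl exceeds the scatter. Also open, from the compounds shown here alone, is whether a longer chain such as propanoyl, or a methylamino group on the same carbonyl carbon, would read like compound 4 or like compound 2 and compound 3.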